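The source may report more compounds than this note shows. Statements on the series, on what has been measured and on what is new or still open speak of the compounds shown alone.

In an ADME assay on Huh-7 cells (Homo sapiens) for cytotoxicity, read by MTT assay, with a stated time of 72 h (a higher number here means that more compound is tolerated, a lower number that less compound is tolerated), compound 1 `Cc1cc(=O)oc2cc(OCc3cn(-c4ccccc4[N+](=O)[O-])nn3)ccc12` gives > 100 ug/mL as a limit of the assay, not a number. Compound 2 `Cc1cc(=O)oc2cc(OCc3cn(-c4ccc(Oc5ccccc5)cc4)nn3)ccc12` gives > 100 ug/mL as a limit too. The evidence so far is the limit of > 100 ug/mL in this assay, at which 2 of the 2 values shown sit, and nothing finer. Compound 3 `Cc1cc(=O)oc2cc(OCc3c[nH]nn3)ccc12` differs from compound 1 by hydrogen in place of 2-nitrophenyl on an aromatic nitrogen, counted in full as hydrogen in place of 2-nitrophenyl on an aromatic nitrogen in the structures. Among the compounds with values here, no measured step is available to guide the expectation, so the expected change a number no higher from compound 1 to compound 3 (the limit leaves the size open) is none beyond the scatter in this assay in either direction. For compound 3 the estimated value is 100 ug/mL with an expected range from 45 ug/mL to 220 ug/mL in this read-out.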

Compound 3, half-maximal cytotoxic concentration: > 100 ug/mL
Compound 3 gave a limit, no number (the forecaster's own chance of this, stated with the estimate: 70%); the middle value lies on the limit itself.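

Within the data shown here, compound 1 and compound 3 both give a limit rather than a number in this assay, and no step between them can be read. The compounds shown leave open whether 2-nitrophenyl or hydrogen on the aromatic nitrogen makes any difference in this read-out.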